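Aryl urea variation on the shared core: compound 4

The source may hold more compounds than are shown below. What is called first, only, known or untested is meant among the compounds shown, and "the series" means these compounds.

The series varies the aryl group on the urea of a shared core and is read in a functional assay on RT-112 cells (Homo sapiens) for antiproliferative activity, read by MTT assay, with a stated time of 72 h; on this read-out higher numbers stand for weaker inhibition of growth and lower numbers for stronger inhibition of growth. Compound 1 `COc1cc(Nc2ncnc3c(NC(=O)Nc4cc(F)cc(F)c4)cccc23)cc(OC)c1` gives 2630 nM in this assay. Compound 2 `COc1cc(Nc2ncnc3c(NC(=O)Nc4ccc(F)cc4C(F)(F)F)cccc23)cc(OC)c1` gives 2970 nM, and compound 3 `COc1cc(Nc2ncnc3c(NC(=O)Nc4cc(C(F)(F)F)cc(C(F)(F)F)c4)cccc23)cc(OC)c1` gives 467 nM. Among these three numbers compound 1 stands second highest: compound 2 is within the scatter of it, while compound 3 sits clearly lower, beyond the scatter.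

Compound 4 `COc1cc(Nc2ncnc3c(NC(=O)Nc4ccc(C(F)(F)F)cc4Cl)cccc23)cc(OC)c1` is not yet measured. It differs from compound 1 in one place: 2-chloro-4-(trifluoromethyl)phenyl in place of 3,5-difluorophenyl on an amide-type nitrogen. Going by the values given here, the only measured step of the same kind, a 1.1-fold higher number from compound 1 to compound 2 (0.05 log units; within the scatter), exchanged one aryl for another on the same amide-type nitrogen and stayed within the scatter. Compound 3 is not a single step from compound 1, but compound 3 does give a clearly lower number than compound 1 with a differently substituted aryl at this position. Compound 4 carries a chloro and a trifluoromethyl on its aryl, and on these two data points a modest move toward lower numbers is expected, of a size that may not exceed the scatter, with a 1.8-fold lower number from compound 1 to compound 4 (0.24 log units; within the scatter) as the expected step. Compound 4 is estimated at 1500 nM in this assay, with a range from 600 nM to 4000 nM.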

Compound 4, concentration for 50% growth inhibition: 1080 nM
Compound 4: middle estimate off by 1.4-fold (0.14 log units), on the high side, and the stated range covers the measured number.
By their numbers in this assay, from the lowest: compound 3; then compound 4; then compounds 1 and 2 (each within the scatter of the next).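

In this assay, going by these compounds alone, this is the first exchange of one aryl for another on the amide-type nitrogen to pass beyond the scatter, with both steps modest (a 2.4-fold lower number from compound 1 to compound 4 (0.39 log units; beyond the scatter); a 2.8-fold lower number from compound 2 to compound 4 (0.44 log units; beyond the scatter)), whereas the earlier exchange stayed within it (a 1.1-fold higher number from compound 1 to compound 2 (0.05 log units; within the scatter)). The position therefore distinguishes among substituted aryls, and 2-chloro-4-(trifluoromethyl)phenyl gives a lower number than either 3,5-difluorophenyl or 4-fluoro-2-(trifluoromethyl)phenyl; a trifluoromethyl on the aryl does not alone mark the lower numbers, as compound 2 also carries one and stays within the scatter of compound 1. No measurement is available that explains this difference.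

Compounds 2 and 4 differ in both the halogen and the placement of the trifluoromethyl, so the contribution of each to the step remains unresolved. The compounds shown also leave open how this position responds to an aryl carrying a morpholine or a carboxylic acid, or to an unsubstituted phenyl.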